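The source may hold more compounds than are shown below. What is called first, only, known or untested is meant among the compounds shown, and "the series" means these compounds.

Compound 1, with structure `OB1OCc2ccc(-n3cccc3)cc21`, carries a pyrrole on the shared core. In an ADME assay on L929 cells (Mus musculus) for cytotoxicity, read by resazurin assay, with a stated time of 72 h (a lower number here means a stronger inhibitor, a higher number a weaker inhibitor), compound 1 gives only a limit, > 10 ug/mL, and not a number. Compound 2, with structure `CCNC(=O)c1cccn1-c1ccc2c(c1)B(O)OC2`, differs from compound 1 by an ethylcarbamoyl in place of hydrogen on an aromatic carbon. In this assay compound 2 likewise gives only a limit, > 10 ug/mL. The step that the two limits leave unreadable from compound 1 to compound 2 therefore cannot be read, since both compounds sit at the limit of > 10 ug/mL in this assay, at which 2 of the 2 values shown sit. Where compound 1 stands is thus known only as a limit, and the single other value shown is a limit as well.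

Compound 3, with structure `OB1OCc2ccc(-n3ccc(Cc4ccccc4)c3)cc21`, is not yet measured. It differs from compound 1 by benzyl in place of hydrogen on an aromatic carbon. No measured step bears on this change in a readable way, because the only step shown, a step that the two limits leave unreadable from compound 1 to compound 2, is hidden by the two limits. For compound 3 in this assay an outcome near the same limit is expected, and the estimate is 12 ug/mL, within 4 ug/mL to 40 ug/mL. The expected step that the limit leaves unreadable from compound 1 to compound 3 is accordingly estimated as small, with a limit again the likeliest report.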

Compound 3, half-maximal inhibitory concentration: > 10 ug/mL
Compound 3: a limit, no number; the forecaster's own chance of this, stated with the estimate: 60%; the middle value is on the limit's open side.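

In this assay compound 3 gives > 10 ug/mL, a limit and not a number. The step from compound 1 to compound 3 cannot be read, because the values sit at one limit: the limit of > 10 ug/mL in this assay, at which 3 of the 3 values shown sit.

The compounds shown leave open how far the true values of compound 1, compound 2 and compound 3 lie beyond that limit, and whether benzyl or ethylcarbamoyl changes them at all.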